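Fluoro for Trifluoromethyl: Expected Cytotoxicity of Compound 4

A few compounds are considered here, and "the series" means these few. Any claim that something is new, unique, unknown or untested is made for them only; others in the source may bear on it.

Compound 1 `Cc1cc(C#N)cc(C)c1Oc1nc(Nc2ccc(C#N)cc2)ncc1-c1ccccc1`: 31800 nM
Compound 2 `Cc1cc(C#N)cc(C)c1Oc1nc(Nc2ccc(C#N)cc2)ncc1-c1ccco1`: a limit of the assay, > 306000 nM
Compound 3 `Cc1cc(C#N)cc(C)c1Oc1nc(Nc2ccc(C#N)cc2)ncc1-c1ccc(C(F)(F)F)cc1`: 35000 nM

All three were tested in an ADME assay on MT4 cells (Homo sapiens) for cytotoxicity, read by MTT assay, with a stated time of 5 days; on this read-out lower numbers stand for higher toxicity in this test and higher numbers for lower toxicity in this test. Compound 3 has the highest of the two plain numbers, but the step of a 1.1-fold higher number from compound 1 to compound 3 (0.04 log units; within the scatter) lies within the scatter, so the two cannot be ranked. Compound 2 sits at a limit, (the limit of > 306000 nM in this assay, at which 1 of the 3 values shown sits). Compound 4 `Cc1cc(C#N)cc(C)c1Oc1nc(Nc2ccc(C#N)cc2)ncc1-c1ccc(F)cc1` is not yet measured; it differs from compound 3 by fluoro in place of trifluoromethyl on an aromatic carbon. Among the compounds with values here, the only measured step touching this part of the structure is a 1.1-fold higher number from compound 1 to compound 3 (0.04 log units; within the scatter), where a trifluoromethyl replaced a hydrogen and the number stayed within the scatter. Exchanging that trifluoromethyl for a fluoro is therefore expected to give no step beyond the scatter, a 1.1-fold lower number from compound 3 to compound 4 (0.03 log units; within the scatter). Compound 4 is estimated at 33000 nM, between 15000 nM and 75000 nM.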

Compound 4, half-maximal cytotoxic concentration: 42700 nM
The estimate for compound 4 lay 1.3-fold (0.11 log units) below the measured number, and the stated range covers the measured number.
By their numbers in this assay, from the lowest: compounds 1, 3 and 4 (each within the scatter of the next). At a limit, above all of these: compound 2.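

In this assay, hydrogen, fluoro and trifluoromethyl on the aromatic carbon para to a large group cannot be told apart: a 1.2-fold higher number from compound 3 to compound 4 (0.09 log units; within the scatter), and a 1.3-fold higher number from compound 1 to compound 4 (0.13 log units; within the scatter). The clear separation lies with the ring itself, with an at least 7.1-fold lower number from compound 2 to compound 4 (0.85 log units; beyond the scatter). Compound 2 remains a limit of the assay, not a plain number: the limit of > 306000 nM in this assay, at which 1 of the 4 values shown sits.

On these data alone, whether an amine or a carboxylic acid at this para carbon would shift the number beyond the scatter stays open. Also open, as far as these compounds go, is whether a thiophene in place of furan-2-yl would stay as far from the six-membered rings.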